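Acetyl pyrazoline series: swapping the aryl on the saturated carbon

The source may report more compounds than this note shows. Statements on the series, on what has been measured and on what is new or still open speak of the compounds shown alone.

Measured compounds:
compound 1 `COc1ccc(C2OC(c3cc(OC)c(OC)c(OC)c3)=NN2C(C)=O)c(OC)c1` gives 69.5%
compound 2 `COc1cc(C2=NN(C(C)=O)C(c3cc(OC)c(OC)c(OC)c3)O2)cc(OC)c1OC` gives -1.8%
compound 3 `COc1cc(/C=N/NC(=O)c2cc(OC)c(OC)c(OC)c2)cc(OC)c1OC` gives 8.5%

In a functional assay on PC-3 cells (Homo sapiens) for antiproliferative activity, read by MTT assay, tested at 1 uM (on this read-out lower numbers stand for a weaker effect and higher numbers for a stronger effect at the one concentration tested), compound 1 stands highest of the three numbers. Its nearest neighbour is compound 3, whose value is lower by a margin beyond the scatter, and compound 2, which shares the core of compound 1 but carries a trimethoxyphenyl on the saturated ring carbon, lies furthest off with a value that is essentially nil.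

Compound 4 `COc1cc(C2=NN(C(C)=O)C(c3ccc(Cl)c([N+](=O)[O-])c3)O2)cc(OC)c1OC` is not yet measured. It differs from compound 1 in one place: 4-chloro-3-nitrophenyl in place of 2,4-dimethoxyphenyl on a saturated ring carbon. Within the data shown here, no step between measured compounds isolates this change, so there is nothing to compute from. What the three values show is that the group on the saturated ring carbon can carry the whole difference between a strong and an absent effect, since compound 2 gives -1.8% against compound 1.

Compound 4 is therefore expected to sit below compound 1, with the step of a number 41.5 percentage points lower from compound 1 to compound 4 (beyond the scatter) estimated as a loss beyond the scatter, though of uncertain size. The value of compound 4 in this assay is estimated at 28%, within a range from -5% to 62%.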

Compound 4, a percentage reported as inhibition, at one concentration (the size of the read-out at that concentration, not a potency): 43.3%
For compound 4 the middle estimate is 15.3 percentage points below the measured one, and the stated range covers the measured number.
By their numbers in this assay, from the lowest: compound 2; then compound 3; then compound 4; then compound 1.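

In this assay the change to 4-chloro-3-nitrophenyl on the saturated ring carbon is a number 26.2 percentage points lower from compound 1 to compound 4 (beyond the scatter), a partial loss rather than a complete one. An aryl group with no methoxy group at this position therefore still leaves a measurable effect, with compound 2 at -1.8% and compound 4 at 43.3%, so the near-nil value of compound 2 does not set the outcome for every replacement here. No measured information is available to explain the difference between these aryl groups. The compounds shown do not separate the contribution of the chloro group from that of the nitro group, or of one methoxy group from the other. From the compounds shown here alone, it also remains open how an unsubstituted phenyl, or an aryl group bearing an amine or a carboxylic acid, would behave at this carbon.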